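The compounds below may be only part of what the source reports. "The series", "measured", "known", "first", "only" and "open" are said of these compounds alone.

Of the compounds shown here, two have been tested in an in vitro functional assay on HEK285-7 cells for antagonist activity at prostaglandin D2 receptor 2 (Homo sapiens), read by BRET and beta-arrestin recruitment; on this read-out lower numbers stand for smaller maximal responses and higher numbers for larger maximal responses. Compound 1, `COc1cc(-c2nc(C(c3ccc(F)cc3)c3ccc(F)cc3)sc2CC(=O)O)ccn1`, gives 60% in this assay, and compound 2, `O=C(O)Cc1sc(Cc2ccccc2)nc1-c1ccc(Cl)cc1`, gives 50%. These two numbers lie within the usual scatter of each other, so compound 1 cannot be set apart from compound 2 on this read-out, and nothing can be said about which of the two responds more strongly.

Compound 3, `O=C(O)Cc1sc(C(c2ccc(F)cc2)c2ccc(F)cc2)nc1-c1cccc(F)c1`, has not yet been measured in this assay. It is built from compound 1 by a single change: 3-fluorophenyl in place of 2-methoxypyridin-4-yl on an aromatic carbon. Compound 2 also carries a different group at this place on the core, but it differs from compound 1 elsewhere as well, so it cannot serve as a clean comparison for this exchange. Within the data shown here, no measured pair of compounds here shows what this kind of swap does to the maximal response. On that basis the step from compound 1 to compound 3 is expected to be small, a number 5 percentage points lower from compound 1 to compound 3 (within the scatter), with no direction that can be told from the scatter. Compound 3 is therefore estimated to reach 55% in this assay, within a range from 35% to 75%.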

Compound 3, largest response reached (reported as efficacy), in percent of the reference or control that the assay uses: 80%
For compound 3 the middle estimate is 25 percentage points below the measured one, outside the stated range (above it).
By their numbers in this assay, from the lowest: compounds 2 and 1 (each within the scatter of the next); then compound 3.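

In this assay, placing 3-fluorophenyl instead of 2-methoxypyridin-4-yl on this aromatic carbon, next to the ring nitrogen, gives a number 20 percentage points higher from compound 1 to compound 3 (beyond the scatter). Among these compounds, this is the first comparison here in which only this group changes, and it shows that the maximal response depends on what sits at this position, at least for this pair on this core. The exchange alters several things at once, removing the ring nitrogen and the methoxy group with their two counted hydrogen-bond acceptors and adding a fluorine, and no information is available that explains the change in response.

This single pair cannot show which of those differences matters, or whether the same exchange would have a similar outcome with other groups elsewhere on the core. An unsubstituted phenyl ring would help separate these contributions, as would a methoxyphenyl group or a pyridinyl ring carrying no methoxy group, since each of these keeps only part of the difference between the two groups compared here.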